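A few compounds are considered here, and "the series" means these few. Any claim that something is new, unique, unknown or untested is made for them only; others in the source may bear on it.

Within the data shown here, in a toxicity assay on GES1 cells (Homo sapiens) for inhibition, read by MTT assay, with a stated time of 72 h (on this read-out higher numbers stand for weaker inhibition and lower numbers for stronger inhibition), compound 1 (`Cc1cc(N2CC[C@@H](C)[C@@H](N(C)c3ncnc4[nH]ccc34)C2)n2nc(SCC3CC3)nc2n1`) gives 27900 nM, the lower of the two numbers so far. Compound 2 (`Cc1nc2nc(SCc3ccc(Cl)cc3)nn2c(N2CC[C@@H](C)[C@@H](N(C)c3ncnc4[nH]ccc34)C2)c1C`) gives 99200 nM, a gap beyond the usual scatter. Compound 3 (`Cc1cc(N2CC[C@@H](C)[C@@H](N(C)c3ncnc4[nH]ccc34)C2)n2nc(SCCc3ccccc3)nc2n1`) keeps the core of compound 1 and has benzyl in place of cyclopropyl on a saturated chain carbon bound to a sulfur. Among the measured compounds shown here, no measured pair isolates this change, and only a small shift towards weaker inhibition, within the scatter, is expected. The estimated step is a 1.3-fold higher number from compound 1 to compound 3 (0.10 log units; within the scatter) in this assay. For compound 3 the expected value is 35000 nM, with an estimated range of 13000 nM to 90000 nM.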

Compound 3, half-maximal inhibitory concentration: 66200 nM
Compound 3: the middle estimate sits 1.9-fold (0.28 log units) below what was measured, and the stated range covers the measured number.
By their numbers in this assay, from the lowest: compound 1; then compounds 3 and 2 (each within the scatter of the next).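

In this assay, among these compounds, the first matched step on this saturated chain carbon bound to a sulfur reads a 2.4-fold higher number from compound 1 to compound 3 (0.38 log units; beyond the scatter) and goes towards weaker inhibition. The number at this place therefore responds to the group it carries, though only modestly for benzyl in place of cyclopropyl. No measured evidence accounts for this step.

Cyclopropylmethyl to phenethyl changes both the ring and the chain, and this single pair cannot separate the two. As far as these compounds go, how a cyclohexyl group or a terminal amine would read at this place remains open.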